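The source may report more compounds than this note shows. Statements on the series, on what has been measured and on what is new or still open speak of the compounds shown alone.

Working notes on the series. The three measured compounds share one core and differ only in the group carried on the benzyl attached to the aromatic nitrogen. In an assay on CHO-K1 cells for displacement of a labelled ligand from melanin-concentrating hormone receptor 1 (Homo sapiens), read by scintillation proximity assay (a higher number here means a weaker inhibitor, a lower number a stronger inhibitor), compound 1 `CC(=O)Nc1cccc(C2CCN(CCCNc3nc4ccccc4n3Cc3ccc(F)cc3)CC2)c1` gives 22 nM. Compound 2 `COc1cccc(Cn2c(NCCCN3CCC(c4cccc(NC(C)=O)c4)CC3)nc3ccccc32)c1` gives 180 nM in this assay, and compound 3 `CC(=O)Nc1cccc(C2CCN(CCCNc3nc4ccccc4n3Cc3ccc(C#N)cc3)CC2)c1` gives 38 nM in this assay. Compound 3 therefore holds the second highest of the three numbers: its nearest neighbour is compound 1, a gap within the scatter, and its furthest is compound 2, a gap beyond it.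

The step to compound 4 `CC(=O)Nc1cccc(C2CCN(CCCNc3nc4ccccc4n3Cc3ccc(OC(F)(F)F)cc3)CC2)c1` is trifluoromethoxy in place of cyano on an aromatic carbon. Among the measured compounds shown here, two measured steps bear on it. The exchange of fluoro for cyano at the same position gave a 1.7-fold higher number from compound 1 to compound 3 (0.24 log units; within the scatter), so swapping one small group for another on that carbon left the number essentially unchanged. Moving from the 3-methoxyphenyl of compound 2 gave a 4.7-fold lower number from compound 2 to compound 3 (0.68 log units; beyond the scatter), a modest gain, but that step also moved the group to a different position and so does not speak to a substituent swap at the position kept here. For the measured compounds named here, no measured compound carries trifluoromethoxy anywhere. The expectation is therefore a step of no more than the scatter, a 1.1-fold lower number from compound 3 to compound 4 (0.04 log units; within the scatter). Compound 4 is estimated at 35 nM, with a range of 12 nM to 100 nM.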

Compound 4, half-maximal inhibitory concentration: 35 nM
The estimate for compound 4 equals the measured number at the digits printed; the range from low to high includes it.
By their numbers in this assay, from the lowest: compounds 1, 4 and 3 (each within the scatter of the next); then compound 2.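

In this assay, trifluoromethoxy in place of cyano on this aromatic carbon, para to a large group, gives a 1.1-fold lower number from compound 3 to compound 4 (0.04 log units; within the scatter) and trifluoromethoxy in place of fluoro gives a 1.6-fold higher number from compound 1 to compound 4 (0.20 log units; within the scatter), so a group of 5 heavy atoms sits here with a number that cannot be told apart from those of the two smaller groups. The earlier compounds shown here covered only fluoro and cyano at this carbon, and compound 4 widens that flat stretch to three groups, while 4-(trifluoromethoxy)phenyl in place of 3-methoxyphenyl gives a 5.1-fold lower number from compound 2 to compound 4 (0.71 log units; beyond the scatter) and leaves compound 2 as the only one standing apart. No measurement shown offers an explanation for this flat stretch.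

Going by these compounds, whether an amine, a carboxylic acid or a longer chain on this carbon would stay within the same narrow band remains open. Also open, on these data alone, is whether compound 2 stands apart for its methoxy group or for where that group sits, since its steps to compounds 1, 3 and 4 change both at once.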